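Aryl for Methyl on the Ring Nitrogen

A few compounds are considered here, and "the series" means these few. Any claim that something is new, unique, unknown or untested is made for them only; others in the source may bear on it.

Compound 1 `CN1CCN(Cc2csc(N)c2C(=O)c2ccc(Cl)cc2)CC1` carries a methyl on an amine nitrogen in a ring. In an assay on CHO cells for displacement of a labelled ligand from adenosine receptor A1 (Homo sapiens) (a lower number here means tighter binding, a higher number weaker binding), compound 1 gives 1.2 nM. Compound 2 `Nc1scc(CN2CCN(c3ccc(F)cc3)CC2)c1C(=O)c1ccc(Cl)cc1` gives 1 nM in this assay, and compound 3 `Nc1scc(CN2CCN(c3ccc(Cl)cc3)CC2)c1C(=O)c1ccc(Cl)cc1` gives 1.1 nM. All three numbers sit within the usual scatter of one another: a 1.2-fold lower number from compound 1 to compound 2 (0.08 log units; within the scatter), a 1.1-fold lower number from compound 1 to compound 3 (0.04 log units; within the scatter), and a 1.1-fold higher number from compound 2 to compound 3 (0.04 log units; within the scatter). Compound 4 `Cc1ccc(N2CCN(Cc3csc(N)c3C(=O)c3ccc(Cl)cc3)CC2)cc1` differs from compound 1 in one place: 4-methylphenyl in place of methyl on an amine nitrogen in a ring. The two measured steps that bear on it, a 1.2-fold lower number from compound 1 to compound 2 (0.08 log units; within the scatter) and a 1.1-fold lower number from compound 1 to compound 3 (0.04 log units; within the scatter), each replace the methyl at this same position without moving the number beyond the scatter. The resulting step is therefore expected to be a 1.1-fold lower number from compound 1 to compound 4 (0.04 log units; within the scatter), no change beyond the scatter. Compound 4 is estimated at 1.1 nM, within 0.5 nM to 2.5 nM.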

Compound 4, dissociation constant: 1 nM
For compound 4 the middle estimate is 1.1-fold (0.04 log units) above the measured one, and the stated range covers the measured number.
By their numbers in this assay, from the lowest: compounds 2, 4, 3 and 1 (each within the scatter of the next).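

The 4-methylphenyl group on the ring nitrogen also stays within the scatter (a 1.2-fold lower number from compound 1 to compound 4 (0.08 log units; within the scatter)). The earlier aryl groups at this position bore a halogen, and this one bears a carbon group. Direct exchange on the aromatic carbon also stays within the scatter in this assay (a 1.1-fold lower number from compound 3 to compound 4 (0.04 log units; within the scatter) and no change at the digits printed from compound 2 to compound 4 (within the scatter)). No measured evidence explains this flatness.

As far as these compounds go, whether this tolerance extends to a carboxylic acid or an amine on the aromatic ring remains open. So does whether a longer chain on the ring nitrogen would leave the number unchanged.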